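Removing a ring chloro from a purine cytotoxin

A few compounds are considered here, and "the series" means these few. Any claim that something is new, unique, unknown or untested is made for them only; others in the source may bear on it.

Compound 1 `ClCc1cccc(Cn2cnc3nc(Cl)nc(Cl)c32)c1`: 4890 nM
Compound 2 `ClCc1ccc(Cn2cnc3ncnc(Cl)c32)cc1`: 34700 nM

In a functional assay on SK-MEL-5 cells (Homo sapiens) for cytotoxicity, read by sulforhodamine B assay, with a stated time of 48 h (a higher number here means that more compound is tolerated, a lower number that less compound is tolerated), compound 1 gives 4890 nM, the lowest of the two numbers; compound 2 gives 34700 nM, a gap beyond the scatter. Compound 3 `ClCc1cccc(Cn2cnc3ncnc(Cl)c32)c1` is not yet measured. It differs from compound 1 by hydrogen in place of chloro on an aromatic carbon, on the carbon between two ring nitrogen atoms of the shared core. Going by the values given here, compound 2 also carries only one chloro on that core and tolerates far more compound, so the number for compound 3 is expected to rise, with a 4.1-fold higher number from compound 1 to compound 3 (0.61 log units; beyond the scatter) the estimated step. Compound 3 is expected to give about 20000 nM, between 6000 nM and 60000 nM.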

Compound 3, concentration lethal to 50% of the cells: 45700 nM
For compound 3 the middle estimate is 2.3-fold (0.36 log units) below the measured one, within the range that was stated.
By their numbers in this assay, from the lowest: compound 1; then compounds 2 and 3 (each within the scatter of the next).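

In this assay, with the rest of the molecule unchanged, hydrogen in place of chloro on the aromatic carbon between two ring nitrogen atoms gives a 9.3-fold higher number from compound 1 to compound 3 (0.97 log units; beyond the scatter). Going by these compounds alone, compounds 1 and 2 differ in more than one place, so only this pair ties a step beyond the scatter to this chloro alone. No measurement shown here explains the step. Going by these compounds, it remains open whether another group on this carbon, such as an amine or a methoxy group, would keep the lower number of compound 1 or give the higher number of compound 3.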